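From dimethylamino to chloro in a growth-inhibition series

A few compounds are considered here, and "the series" means these few. Any claim that something is new, unique, unknown or untested is made for them only; others in the source may bear on it.

Values so far in a functional assay on HT-29 cells (Homo sapiens) for cytotoxicity, read by sulforhodamine B assay (a higher number here means a weaker inhibitor of growth, a lower number a stronger inhibitor of growth), are these
compound 1 `COc1ccc(/C=N\NC(=S)NC(C)(C)CCC[C@](C)(O)[C@@H]2CC=C(C)CC2)cc1` gives 7420 nM
compound 2 `CC1=CC[C@@H]([C@@](C)(O)CCCC(C)(C)NC(=S)N/N=C\c2ccc(N(C)C)cc2)CC1` gives 27700 nM
compound 3 `CC1=CC[C@@H]([C@@](C)(O)CCCC(C)(C)NC(=S)N/N=C\c2cccc(Cl)c2)CC1` gives 6890 nM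

Of these three, compound 2 has the highest number (27700 nM) and is the weakest inhibitor of growth. Compound 4 (`CC1=CC[C@@H]([C@@](C)(O)CCCC(C)(C)NC(=S)N/N=C\c2ccc(Cl)cc2)CC1`) differs from compound 2 at one place, with chloro in place of dimethylamino on an aromatic carbon, para to a large group (chloro in place of dimethylamino on an aromatic carbon). Going by the values given here, no measured compound yet carries 4-chlorophenyl. The closest guide is a 4.0-fold lower number from compound 2 to compound 3 (0.60 log units; beyond the scatter) and it replaces 4-(dimethylamino)phenyl with 3-chlorophenyl. A step of similar size, a 3.7-fold higher number from compound 1 to compound 2 (0.57 log units; beyond the scatter), brings in dimethylamino in place of methoxy. The remaining step, a 1.1-fold lower number from compound 1 to compound 3 (0.03 log units; within the scatter), shows the 3-chlorophenyl and 4-methoxyphenyl compounds level in this read-out. A modest move to a lower number is therefore expected, and the estimated step is a 4.0-fold lower number from compound 2 to compound 4 (0.60 log units; beyond the scatter) in this assay for this change. Compound 4 is estimated at 7000 nM with an expected range from 3000 nM to 15000 nM as the likely span.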

Compound 4, concentration for 50% growth inhibition: 7350 nM
Beside the measured number, compound 4's estimate is 1.1-fold (0.02 log units) below it; low and high end bracket the measured number.
By their numbers in this assay, from the lowest: compounds 3, 4 and 1 (each within the scatter of the next); then compound 2.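

In this assay, chloro in place of dimethylamino on the aromatic carbon para to a large group gives a 3.8-fold lower number from compound 2 to compound 4 (0.58 log units; beyond the scatter) and shows that the gap between compound 2 and the chloro series does not depend on moving the chloro away from that place. The position of the chloro does not separate the two chloro compounds, with 4-chlorophenyl in place of 3-chlorophenyl giving a 1.1-fold higher number from compound 3 to compound 4 (0.03 log units; within the scatter), and chloro in place of methoxy gives a 1.0-fold lower number from compound 1 to compound 4 (0.00 log units; within the scatter), leaving only the dimethylamino compound apart from the other three. Nothing measured here accounts for why dimethylamino stands apart.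

The compounds shown leave open whether a primary amine or a carboxylic acid at this place would stand with dimethylamino or with chloro and methoxy. They also leave open whether bromo or fluoro would stay level with chloro.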